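The compounds below may be only part of what the source reports. "The series", "measured", "known", "first", "only" and "open" are said of these compounds alone.

Measured so far in an assay for inhibition of Indoleamine 2,3-dioxygenase 1 (Homo sapiens), read by spectrophotometry, with stated times of 1 h and 4 h; a higher number here means a weaker inhibitor, a lower number a stronger inhibitor:
Compound 1 `CC(=O)Nc1ccc(S(=O)(=O)NNc2ccccc2)cc1` gives 71 nM.
Compound 2 `CC(=O)Nc1ccc(S(=O)(=O)NNc2ccc(C)cc2)cc1` gives 51 nM.
Compound 3 `COc1ccc(NNS(=O)(=O)c2ccc(NC(C)=O)cc2)cc1` gives 254 nM.

Compound 3 has the highest number of the three; the other two lie within the scatter of each other, as shown by the step of a 1.4-fold lower number from compound 1 to compound 2 (0.14 log units; within the scatter). Compound 4 `CC(=O)Nc1ccc(S(=O)(=O)NNc2ccc(C#N)cc2)cc1` differs from compound 3 in one place: cyano in place of methoxy on an aromatic carbon. Within the data shown here, two measured steps bear on this position. The step of a 3.6-fold higher number from compound 1 to compound 3 (0.55 log units; beyond the scatter) and the step of a 5.0-fold higher number from compound 2 to compound 3 (0.70 log units; beyond the scatter) both show that the methoxy group goes with a weaker result than hydrogen or methyl there. Among the measured compounds shown here, no measured compound carries a cyano group, so its effect is unknown; the expectation is that compound 4 lands between the methoxy and the hydrogen analogues, a step of a 2.0-fold lower number from compound 3 to compound 4 (0.29 log units; within the scatter) in this assay. Compound 4 is therefore estimated at 130 nM, with a likely range from 45 nM to 400 nM.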

Compound 4, half-maximal inhibitory concentration: 5670 nM
Beside the measured number, compound 4's estimate is 44-fold (1.64 log units) below it; measured number above the stated range.
By their numbers in this assay, from the lowest: compounds 2 and 1 (each within the scatter of the next); then compound 3; then compound 4.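

The earlier compounds shown here spanned a narrow range at this position, but in this assay the change to cyano gives a 22-fold higher number from compound 3 to compound 4 (1.35 log units; beyond the scatter) and so moves the number far more than any earlier step. The steps of an 80-fold higher number from compound 1 to compound 4 (1.90 log units; beyond the scatter) and a 110-fold higher number from compound 2 to compound 4 (2.05 log units; beyond the scatter) place the cyano compound well apart from the others. Methoxy and cyano match in heavy atoms and hydrogen-bond acceptors, so those counts do not track the result here.

Nothing shown explains this loss. As far as these compounds go, whether an amine, a carboxylic acid or a fluorine atom at this position would behave like cyano stays open.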